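A few compounds are considered here, and "the series" means these few. Any claim that something is new, unique, unknown or untested is made for them only; others in the source may bear on it.

Compound 1 (`N#Cc1ccc(/C=C/S(=O)(=O)Cc2ccc(Nc3ncnc4ccccc34)cc2)cc1`) is the starting point here. As far as these compounds go, in a functional assay on DU-145 cells (Homo sapiens) for inhibition (a lower number here means a stronger inhibitor of growth, a higher number a weaker inhibitor of growth), compound 1 gives > 100000 nM, which is a limit of the assay and not a number, so its true position on the scale is unknown. Compound 4 (`O=S(=O)(/C=C/c1ccc(O)cc1)Cc1ccc(Nc2ncnc3ccccc23)cc1`) differs from it at one place, (hydroxy in place of cyano on an aromatic carbon), with hydroxy in place of cyano on an aromatic carbon, para to a large group.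

Among the measured compounds shown here, one measured step touches the same place. With bromo in place of cyano, the data show an at least 1.8-fold lower number from compound 1 to compound 2 (0.25 log units; that floor lies within the scatter), and compound 2 (`O=S(=O)(/C=C/c1ccc(Br)cc1)Cc1ccc(Nc2ncnc3ccccc23)cc1`) gives 55000 nM. That step says little about direction. More useful is compound 3 (`CC(C)(C)c1cc(/C=C/S(=O)(=O)Cc2ccc(Nc3ncnc4ccccc34)cc2)cc(C(C)(C)C)c1O`), which also carries a hydroxy group on that ring, together with further groups, and compound 3 gives 1000 nM.

On the strength of that value, a clear move towards a lower number is expected, though probably not all the way to compound 3, and the estimated change is an at least 10-fold lower number from compound 1 to compound 4 (1.00 log units; beyond the scatter). For compound 4 the expected value is 10000 nM, with an estimated range of 1500 nM to 60000 nM.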

Compound 4, concentration for 50% growth inhibition: 19000 nM
Compound 4: the middle estimate sits 1.9-fold (0.28 log units) below what was measured; low and high end bracket the measured number.
By their numbers in this assay, from the lowest: compound 3; then compound 4; then compound 2. At a limit, above all of these: compound 1.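

In this assay, hydroxy in place of cyano gives an at least 5.2-fold lower number from compound 1 to compound 4 (0.72 log units; beyond the scatter), so the group at this position on the ring can shift the number by more than the usual scatter, which the bromo step alone could not show. Hydroxy in place of bromo gives a 2.9-fold lower number from compound 2 to compound 4 (0.46 log units; beyond the scatter), a modest step and the first at this position read between two actual numbers. The step from compound 1 gives only a floor, and its true size stays unknown, as compound 1 stands at a limit: the limit of > 100000 nM in this assay, at which 1 of the 4 values shown sits.

As far as these compounds go, whether an amine, a methoxy group or a carboxylic acid at this same place would give a lower number than hydroxy stays open. The compounds shown also cannot separate the share of the hydroxy group in compound 3 from that of the further groups on its ring.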